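A few compounds are considered here, and "the series" means these few. Any claim that something is new, unique, unknown or untested is made for them only; others in the source may bear on it.

Three amides built on one shared core have been tested in a functional assay on the whole organism (strain Wistar) for inhibition, with Rattus norvegicus as the target, read by paw edema, with stated times of 60 min and 6 h, at a dose of 100 mg/kg by the oral route; a lower number here means less inhibition, a higher number more inhibition at the dose given (going by the name of the read-out). Compound 1 `CNC(=O)CC1CCc2cc(OC)c(OC)cc21` gives 24.1%, compound 2 `COc1cc2c(cc1OC)C(CC(=O)N(C)C)CC2` gives 33.3%, and compound 3 `COc1cc2c(cc1OC)C(CC(=O)NC1CCCC1)CC2` gives 40.7%. Compound 2 thus sits between the other two numbers and within the scatter of each: a number 9.2 percentage points higher from compound 1 to compound 2 (within the scatter) and a number 7.4 percentage points higher from compound 2 to compound 3 (within the scatter), whereas a number 16.6 percentage points higher from compound 1 to compound 3 (beyond the scatter). Compound 4 `COc1cc2c(cc1OC)C(CC(=O)NCc1ccccc1)CC2` is not yet measured; it differs from compound 2 by benzylamino in place of dimethylamino on a carbonyl carbon. The step bearing most on it is the exchange of the same dimethylamino for cyclopentylamino, which brought a number 7.4 percentage points higher from compound 2 to compound 3 (within the scatter); every change at the amide nitrogen so far moved the number upward, only one beyond the scatter. A similarly small upward step is therefore expected, a number 6.7 percentage points higher from compound 2 to compound 4 (within the scatter). Compound 4 is estimated at 40%, ranging from 26% to 54%.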

Compound 4, a percentage reported as inhibition, in the whole organism at one dose (the size of the read-out at that dose, not a potency): 30.6%
For compound 4 the middle estimate is 9.4 percentage points above the measured one; measured number inside the range.
By their numbers in this assay, from the lowest: compounds 1, 4, 2 and 3 (each within the scatter of the next, the first and the last beyond it).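

In this assay the amide position proves sensitive to which ring enters: benzyl in place of cyclopentyl gives (a number 10.1 percentage points lower from compound 3 to compound 4 (beyond the scatter)), a modest step beyond the scatter. Against dimethylamino, benzylamino makes no readable difference (a number 2.7 percentage points lower from compound 2 to compound 4 (within the scatter)), and the same holds against the methyl amide (a number 6.5 percentage points higher from compound 1 to compound 4 (within the scatter)). No evidence available here explains these results.

From the compounds shown here alone, it remains open how a phenethylamino group would read on this carbonyl carbon. The same applies to a benzylamino group carrying a carboxylic acid or an amine on its ring.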